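The source may report more compounds than this note shows. Statements on the series, on what has been measured and on what is new or still open speak of the compounds shown alone.

In an ADME assay on microsomes from liver (Rattus norvegicus) for metabolic stability, using NADPH, with a stated time of 10 min (a lower number here means that less of the compound is left, a higher number that more of the compound is left), compound 1 `NCCCCN(C[C@@H]1Cc2cccnc2CN1)[C@H]1CCCc2cccnc21` gives 37% and compound 2 `NCCCCN(C[C@@H]1Cc2nccnc2CN1)[C@H]1CCCc2cccnc21` gives 67%. Compound 3 `NC/C=C\CN(C[C@H]1Cc2ncccc2CN1)[C@H]1CCCc2cccnc21` stands lowest of the three at 11%, with both gaps to the others beyond the scatter. Compound 4 `NC(=O)NC/C=C/CN(C[C@H]1Cc2ncccc2CN1)[C@H]1CCCc2cccnc21`, not yet measured, differs from it by a group of 7 heavy atoms (4 carbon, 2 nitrogen, 1 oxygen; no ring) in place of a group of 4 heavy atoms (3 carbon, 1 nitrogen; no ring), on a saturated chain carbon bound to an amine nitrogen. Going by the values given here, no measured pair of compounds differs in one place only, so the data offer no direct guide to the size of this step. Little room for a fall remains because compound 3 stands at 11%. A moderate rise in this assay is therefore expected, and the estimated change is a number 14 percentage points higher from compound 3 to compound 4 (beyond the scatter). For compound 4 the estimated value is 25%, with an expected range from 8% to 50%.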

Compound 4, percent of the compound remaining: 1%
Beside the measured number, compound 4's estimate is 24 percentage points above it, and the stated range ends above it.
By their numbers in this assay, from the lowest: compounds 4 and 3 (each within the scatter of the next); then compound 1; then compound 2.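

In this assay, going by these compounds alone, the larger group on a saturated chain carbon bound to an amine nitrogen gives a number 10 percentage points lower from compound 3 to compound 4 (within the scatter) and so provides the first step in one place, which shows no change beyond the scatter at this position. Both compounds remain near the bottom of the read-out, so this step gives no sign that the added atoms restore the compound remaining. Nothing available bears on the cause of this result.

Going by these compounds, whether a carboxylic acid or a longer chain at this place would leave more of the compound remains open. So does whether the same change would behave alike on the core of compound 2, where more of the compound is left.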